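Swapping Oxiran-2-yl for Fluoro on a Stable Shared Core

The source may report more compounds than this note shows. Statements on the series, on what has been measured and on what is new or still open speak of the compounds shown alone.

Compound 3 `FC(F)(F)c1cc(C2CO2)cc(C(F)(F)F)c1` stands at one edge of what an ADME assay for pharmacokinetics, read by LC-MS, in phosphate buffer, with a stated time of 72 h, at pH 7.4, tested at 250 uM (a higher number here means that the compound lasts longer, a lower number that the compound disappears faster), can report: in this assay compound 3 gives > 50 h, which is a limit rather than a measured number. Compound 1 `O=C1C=CC(=O)N1c1cc(C(F)(F)F)cc(C(F)(F)F)c1` sits at the opposite edge; in this assay compound 1 gives < 0.017 h, also a limit. Compound 2 `N#Cc1cc(C(F)(F)F)cc(C(F)(F)F)c1` in this assay gives > 50 h, again a limit. So two of the three values shown share the upper limit (the limit of > 50 h in this assay, at which 2 of the 3 values shown sit), and one sits at the lower limit (the limit of < 0.017 h in this assay, at which 1 of the 3 values shown sits).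

Compound 4 `Fc1cc(C(F)(F)F)cc(C(F)(F)F)c1` differs from compound 3 by fluoro in place of oxiran-2-yl on an aromatic carbon. The measured steps bear on this only indirectly. The step of an at least 2900-fold higher number from compound 1 to compound 2 (3.46 log units; beyond the scatter) and the step of an at least 2900-fold higher number from compound 1 to compound 3 (3.46 log units; beyond the scatter) both remove the five-membered ring of compound 1 and both reach the upper limit. The step that the two limits leave unreadable from compound 2 to compound 3 cannot be read. Going by the values given here, no measured step exchanges oxiran-2-yl for fluoro.

Since compound 2 and compound 3 both reach the upper limit (the limit of > 50 h in this assay, at which 2 of the 3 values shown sit), compound 4 is expected to stay at that end as well, and the step that the limit leaves unreadable from compound 3 to compound 4 is expected to be no larger than the scatter. For compound 4 the estimate in this assay is 150 h, with a range from 30 h to 1000 h.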

Compound 4, half-life: > 50 h
Compound 4 was reported as a limit (the forecaster's own chance of this, stated with the estimate: 85%); the middle value is on the limit's open side.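

With fluoro, a single atom and no ring, the shared core stays at the upper end, so three different groups at this place on the aromatic carbon now give the same result: the limit of > 50 h in this assay, at which 3 of the 4 values shown sit. Putting one fluorine atom in place of the five-membered ring group gives an at least 2900-fold higher number from compound 1 to compound 4 (3.46 log units; beyond the scatter), so even the smallest group shown here differs from that ring group as strongly as cyano and oxiran-2-yl do. The steps among compound 2, compound 3 and compound 4 cannot be read, since all three values are the same limit.

Any difference in half-life among these three therefore stays open. Also open, from the compounds shown here alone, is whether an amine, a carboxylic acid or a longer chain at this place would stay at the upper limit or fall towards the lower one.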